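Iodothiophene Pyrazoline Against Leukemia Cell Growth

The source may hold more compounds than are shown below. What is called first, only, known or untested is meant among the compounds shown, and "the series" means these compounds.

Measured so far:
Compound 1 `O=C(/C=C/c1ccc(N2CCCCC2)cc1)c1ccsc1` gives 32100 nM in an ADME assay on CCRF-CEM cells (Homo sapiens) for cytotoxicity, with a stated time of 5 days; on this read-out higher numbers stand for weaker inhibition and lower numbers for stronger inhibition.
Compound 2 `Cc1ccsc1C(=O)/C=C/c1ccc(N2CCCCC2)cc1` gives 9900 nM.
Compound 3 `c1cc(C2=NNC(c3ccc(N4CCCCC4)cc3)C2)cs1` gives 27000 nM.

On these numbers compound 3 stands second highest of the three; its nearest neighbour is compound 1, within the scatter, while compound 2 lies a step below it. Compound 4 `Ic1ccc(C2=NNC(c3ccc(N4CCCCC4)cc3)C2)s1` differs from compound 3 by 5-iodothiophen-2-yl in place of thiophen-3-yl on a carbon with a double bond to nitrogen. For the measured compounds named here, the only measured step, a 3.2-fold lower number from compound 1 to compound 2 (0.51 log units; beyond the scatter), sits on a carbonyl carbon, a different place, with a methyl rather than an iodine, so it bears only loosely here; it does show a substituted thiophene giving a modestly lower number. In this assay compound 4 is therefore expected to show a modest lowering, a 1.8-fold lower number from compound 3 to compound 4 (0.26 log units; within the scatter), though none beyond the scatter would not surprise. Compound 4 is estimated at 15000 nM, within 5000 nM to 45000 nM.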

Compound 4, half-maximal inhibitory concentration: 36500 nM
Beside the measured number, compound 4's estimate is 2.4-fold (0.39 log units) below it; low and high end bracket the measured number.
By their numbers in this assay, from the lowest: compound 2; then compounds 3, 1 and 4 (each within the scatter of the next).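

In this assay, this is the first change shown on a carbon with a double bond to nitrogen, and 5-iodothiophen-2-yl in place of thiophen-3-yl gives a 1.4-fold higher number from compound 3 to compound 4 (0.13 log units; within the scatter). The exchange therefore leaves compound 3 and compound 4 indistinguishable, so neither the added iodine nor the altered thiophen attachment separates them here. No available evidence accounts for this result.

From the compounds shown here alone, because the iodine and the attachment change together, their separate contributions remain open. Also open, going by these compounds, is whether an amine or a carboxylic acid on the thiophene at this position would separate from compound 3.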